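The source may report more compounds than this note shows. Statements on the series, on what has been measured and on what is new or still open speak of the compounds shown alone.

Compound 1 `CCOC(=O)c1c(C)coc1-c1ccc2c(CC)cccc2c1OC` was tested in a functional assay on KBVIN cells (Homo sapiens) for cytotoxicity, read by MTT assay, with a stated time of 72 h (on this read-out lower numbers stand for an effect already at smaller amounts and higher numbers for an effect only at larger amounts of compound), where compound 1 gives 1.8 ug/mL. Compound 2 `CCCOC(=O)c1c(C)coc1-c1ccc2c(CC)cccc2c1OC` differs from compound 1 by methyl in place of hydrogen on a saturated chain carbon, two bonds along the chain from an oxygen next to a carbonyl group. In this assay compound 2 reaches only a limit, > 10 ug/mL, and not a number. That change therefore produced an at least 5.5-fold higher number from compound 1 to compound 2 (0.74 log units; beyond the scatter). Compound 3 `CCc1cccc2c(OC)c(-c3occ(C)c3COC)ccc12` carries a different core than compound 1; the two cores differ by methoxymethyl in place of ethoxycarbonyl on an aromatic carbon. In this assay compound 3 gives 8.8 ug/mL, which is a 4.9-fold higher number from compound 1 to compound 3 (0.69 log units; beyond the scatter). Compound 2 and compound 3 show an at least 1.1-fold lower number from compound 2 to compound 3 (0.05 log units; that floor lies within the scatter).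

Compound 4 `CCOc1c(-c2occ(C)c2COC)ccc2c(CC)cccc12` has not yet been measured in this assay. It differs from compound 3 by methyl in place of hydrogen on a saturated chain carbon bound to an oxygen on an aromatic ring. This is the same kind of change as from compound 1 to compound 2, but not the same: in the earlier pair the added methyl sits on a saturated chain carbon, two bonds along the chain from an oxygen next to a carbonyl group, whereas here it sits on a saturated chain carbon bound to an oxygen on an aromatic ring. Because the earlier pair showed an at least 5.5-fold higher number from compound 1 to compound 2 (0.74 log units; beyond the scatter), a similar weakening is expected here, though with less confidence since the surroundings of the change differ. For compound 4 in this assay a step of a 2.3-fold higher number from compound 3 to compound 4 (0.36 log units; beyond the scatter) is expected. Compound 4 is thus estimated at 20 ug/mL, with a likely range from 8 ug/mL to 60 ug/mL.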

Compound 4, concentration for half-maximal effect: 5.9 ug/mL
Compound 4: the middle estimate sits 3.4-fold (0.53 log units) above what was measured, and the stated range ends above it.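

In this assay, the methyl that turns methoxy into ethoxy gives a 1.5-fold lower number from compound 3 to compound 4 (0.17 log units; within the scatter), so compound 3 and compound 4 cannot be told apart on this read-out. This is a different result from the one seen when a methyl was added to the ester chain of compound 1, which gave an at least 5.5-fold higher number from compound 1 to compound 2 (0.74 log units; beyond the scatter), so in this series the effect of adding a methyl did not carry from one core to the other: the same change on two cores in this assay, an at least 5.5-fold higher number (0.74 log units; beyond the scatter) from compound 1 to compound 2 and a 1.5-fold lower number (0.17 log units; within the scatter) from compound 3 to compound 4, at least 8.2-fold (0.91 log units) apart, beyond the scatter of two such steps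

What this does not show is why the two steps part, since the methyl also sits in a different place in each pair, and two pairs cannot set a rule for the series. Compound 2 reaches only a limit, > 10 ug/mL, and not a number, so the full size of the earlier step stays unknown: the limit of > 10 ug/mL in this assay, at which 1 of the 4 values shown sits.

The compounds shown leave open whether a longer chain, such as propoxy in place of the ethoxy of compound 4, would also stay within the scatter of compound 3. They also leave open how an amine or a carboxylic acid in place of the methoxymethyl would read in this assay.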